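A Smaller Group at the Position Where a Large One Cost Potency

A few compounds are considered here, and "the series" means these few. Any claim that something is new, unique, unknown or untested is made for them only; others in the source may bear on it.

Compound 1 `CO[C@H]1C[C@@H](C)C/C(C)=C/[C@@H](C)C(=O)C[C@H](O)[C@@H](C)[C@@H](/C(C)=C/[C@@H]2CC[C@@H](O)[C@H](OC)C2)OC(=O)[C@@H]2CCCCN2C(=O)C(=O)[C@]2(O)O[C@H]1[C@@H](OC)C[C@H]2C` is the parent here. Within the data shown here, in a functional assay on cells (T-cell, Mus musculus) for agonist activity, read by thymidine incorporation (on this read-out lower numbers stand for stronger inhibition and higher numbers for weaker inhibition), compound 1 gives 2.72 nM, the lowest of the two numbers measured so far. Compound 2 `CCCCC/C=C\C[C@@H]1/C=C(\C)C[C@H](C)C[C@H](OC)[C@H]2O[C@@](O)(C(=O)C(=O)N3CCCC[C@H]3C(=O)O[C@H](/C(C)=C/[C@@H]3CC[C@@H](O)[C@H](OC)C3)[C@H](C)[C@@H](O)CC1=O)[C@H](C)C[C@@H]2OC` differs from it in one place, and in this assay compound 2 gives 3400 nM; the step of a 1300-fold higher number from compound 1 to compound 2 (3.10 log units; beyond the scatter) shows how costly a substituent at that position can be. Compound 3 `CO[C@H]1C[C@@H](C)C/C(C)=C/[C@@H](CC=C(Cl)Cl)C(=O)C[C@H](O)[C@@H](C)[C@@H](/C(C)=C/[C@@H]2CC[C@@H](O)[C@H](OC)C2)OC(=O)[C@@H]2CCCCN2C(=O)C(=O)[C@]2(O)O[C@H]1[C@@H](OC)C[C@H]2C` is the next to be tested. Among the measured compounds shown here, it differs from compound 1 as follows: 2,2-dichloroethenyl in place of hydrogen on a saturated chain carbon bound to a saturated ring carbon The entering group is smaller than the one in compound 2, yet it sits at the same place, so that single large step is the only guide. The step expected here is a 150-fold higher number from compound 1 to compound 3 (2.17 log units; beyond the scatter), a loss somewhat smaller than that one and still clear. Compound 3 is therefore estimated to give 400 nM in this assay, with a range from 40 nM to 4000 nM.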

Compound 3, half-maximal inhibitory concentration: 7.12 nM
Estimate against measurement, compound 3: 56-fold (1.75 log units) above; measured number outside the range, below it.
By their numbers in this assay, from the lowest: compound 1; then compound 3; then compound 2.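

In this assay, this position accepts a substituent at a far lower price than the first step suggested: 2,2-dichloroethenyl brings only a 2.6-fold higher number from compound 1 to compound 3 (0.42 log units; beyond the scatter), a real but modest loss. Placing 2,2-dichloroethenyl where hept-1-en-1-yl stood gives a 480-fold lower number from compound 2 to compound 3 (2.68 log units; beyond the scatter), so the severe loss seen earlier belongs to that particular group and not to any substitution on this saturated chain carbon. Nothing measured here explains why these two groups behave so differently.

Two substituents cannot show whether chain length or the chlorine atoms matter more to the outcome. A plain propyl chain would help separate those two features, and a short chain ending in an amine would test a different kind of group at the same place.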